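Aryloxypropoxy variations on a shared core

This account rests on a few compounds, and the source may have more. Where it says the series, first, only, none or still open, it means among the compounds named here.

Measured compounds:
Compound 1, `NC1=NC2(CCOCC2)N(OCCCOc2ccccc2Cl)C(N)=N1`: in an assay on isolated protein for inhibition of Dihydrofolate reductase (Homo sapiens), read by spectrophotometry, using NADPH, with stated times of 5 s and 6 min (a higher number here means a weaker inhibitor, a lower number a stronger inhibitor), compound 1 gives "not determined" (no result reported).
Compound 2, `NC1=NC2(CCOCC2)N(OCCCOc2ccc(Cl)c(Cl)c2)C(N)=N1`: in this assay compound 2 gives 8.23 nM.
Compound 3, `NC1=NC2(CCOCC2)N(OCCCOc2cccc(Br)c2)C(N)=N1`: in this assay compound 3 gives "not determined" (no result reported).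

Compound 3 stands without a number in this assay, and the same holds for compound 1. Among the compounds with values here, compound 2 is the only member of the series with a stated value, so no step between measured compounds can be drawn, and nothing here shows how a change on the aryl part moves the read-out in either direction.

Compound 4, `Cc1ccc(OCCCON2C(N)=NC(N)=NC23CCOCC3)cc1`, is yet to be measured. It differs from compound 3 by 4-methylphenyl in place of 3-bromophenyl on an oxygen on a saturated carbon. Within the data shown here, with no number for compound 3 and no step in the set, the size of this change cannot be anticipated from the data; the only anchor is that compound 2 gives 8.23 nM. On that anchor alone compound 4 is expected to land in the same general region, with a wide margin on either side. The estimate for compound 4 is 25 nM, expected to fall between 5 nM and 150 nM.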

Compound 4, half-maximal inhibitory concentration: 56.8 nM
Compound 4: the middle estimate sits 2.3-fold (0.36 log units) below what was measured; measured number inside the range.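

In this assay, the aryl group on the oxygen on a saturated carbon gives its first readable step: 4-methylphenyl in place of 3,4-dichlorophenyl produces a 6.9-fold higher number from compound 2 to compound 4 (0.84 log units; beyond the scatter) in the read-out. Within the data shown here, this position is therefore not indifferent to the aryl group, and within this one pair the 3,4-dichlorophenyl compound is the stronger inhibitor, although the single step cannot separate the contributions of the two chlorines and the methyl group. No measurement shown accounts for the step.

Steps to compound 1 and compound 3 cannot be read: neither carries a number. Also open, going by these compounds, is how the read-out responds to an amine or a carboxylic acid on the aryl ring, or to a chain longer than the propoxy link to the shared core.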